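Series notes: 4-hydroxyphenyl in place of 3-chlorophenyl

The compounds below may be only part of what the source reports. "The series", "measured", "known", "first", "only" and "open" are said of these compounds alone.

Two compounds of this series have numbers in an ADME assay on Vero cells (Chlorocebus sabaeus) for cytotoxicity, read by neutral red uptake, tested at 197 ug/mL; a lower number here means a stronger effect, a higher number a weaker effect of the compound at the concentration tested. Compound 1 `O=C1CSC(c2c(Cl)cccc2Cl)N1CCN1CCCCC1` gives 75% in this assay. Compound 2 `O=C1CSC(c2cccc(Cl)c2)N1CCN1CCCCC1` gives 77% in this assay, the higher of the two numbers, with compound 1 as its nearest neighbour; the two numbers lie within the scatter of each other, so no order between them is claimed. Among the measured compounds shown here, no step between measured compounds that differ in one place is available, and both numbers sit in the same region.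

Compound 3 `O=C1CSC(c2ccc(O)cc2)N1CCN1CCCCC1` is not yet measured. Its structure differs from compound 2 by 4-hydroxyphenyl in place of 3-chlorophenyl on a saturated ring carbon. With only the two close numbers for guidance, compound 3 is expected to stay in the same region in this assay, at an estimated 76% (range 58% to 92%). The expected step is a number 1 percentage points lower from compound 2 to compound 3 (within the scatter), which is not beyond the scatter.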

Compound 3, a percentage reported as activity, at one concentration (the size of the read-out at that concentration, not a potency): 87%
Compound 3: middle estimate off by 11 percentage points, on the low side; the measured number falls inside the stated range.
By their numbers in this assay, from the lowest: compounds 1, 2 and 3 (each within the scatter of the next, the first and the last beyond it).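

Among the compounds shown here, the first one-place step, for 4-hydroxyphenyl in place of 3-chlorophenyl on the saturated ring carbon, reads in this assay as a number 10 percentage points higher from compound 2 to compound 3 (within the scatter). Compounds 1 and 2 both carried chlorine on the phenyl ring, and compound 3 shows that this position takes a chlorine-free phenyl bearing a hydroxyl group without a step beyond the scatter. No measurement at hand bears on the reason for this result.

The step exchanges chlorine for hydroxyl and shifts the substituent on the ring at once, so the compounds shown cannot separate the two. Also open, going by these compounds, is how a plain phenyl, or a phenyl carrying an amine or a carboxylic acid, would read in this assay at this position.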